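Adding a nitro group to a weak growth inhibitor

The compounds below may be only part of what the source reports. "The series", "measured", "known", "first", "only" and "open" are said of these compounds alone.

Compound 1 `O=C(CCCCC1CCSS1)NO` - "not active" (no number reported)
Compound 2 `O=C(CCCCC1CCSS1)Nc1cccc(C(F)(F)F)c1` - 6.77%
Compound 3 `O=C(CCCCC1CCSS1)Nc1ccc(OC(F)(F)F)cc1` - 20.3%

In a functional assay on NCI-H460 cells (Homo sapiens) for inhibition, read by MTT assay, with a stated time of 24 h, tested at 10 ug/mL (on this read-out higher numbers stand for more inhibition of growth at the one concentration tested and lower numbers for less inhibition of growth), compound 2 has the lower of the two numbers at 6.77% and compound 3 stands higher at 20.3% by more than the scatter, while compound 1 gave no number. Compound 4 `O=C(CCCCC1CCSS1)Nc1ccc([N+](=O)[O-])c(C(F)(F)F)c1` arises from compound 2 through nitro in place of hydrogen on an aromatic carbon and this nitro sits ortho to a trifluoromethyl group. Going by the values given here, no measured pair shows this change alone, so the expectation stays within the low values seen so far. An expected step of a number 8.2 percentage points higher from compound 2 to compound 4 (within the scatter) in this assay would be upward and within the scatter. For compound 4 the estimated value is 15% with 3% to 35% as its expected range.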

Compound 4, percent growth inhibition at one concentration: 12%
The estimate for compound 4 lay 3 percentage points above the measured number; the measured number falls inside the stated range.
By their numbers in this assay, from the lowest: compounds 2, 4 and 3 (each within the scatter of the next, the first and the last beyond it).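

Nitro in place of hydrogen on this aromatic carbon, ortho to a trifluoromethyl group and para to a large group, gives a number 5.2 percentage points higher from compound 2 to compound 4 (within the scatter) in this assay. At this position, then, adding these three heavy atoms leaves growth inhibition at the one tested concentration indistinguishable from that of the parent compound. Nothing available bears on the reason for this result.

Going by these compounds, whether an amine or a carboxylic acid on this same carbon would give a clearer change remains open. So does what nitro does on a ring lacking the trifluoromethyl group.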